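The source may report more compounds than this note shows. Statements on the series, on what has been measured and on what is new or still open speak of the compounds shown alone.

The series shares one core, a six-membered aromatic ring bearing three aryl groups, and was examined in a functional assay on HCT-15 cells (Homo sapiens) for cytotoxicity, read by CCK-8 assay and cell counting, with a stated time of 2 days; on this read-out lower numbers stand for stronger inhibition and higher numbers for weaker inhibition. Compound 1, `Oc1ccc(-c2cc(-c3cccs3)nc(-c3ccccc3Cl)c2)cc1`, gives 5430 nM. Compound 2, `Oc1cccc(-c2cc(-c3ccc(Cl)cc3)nc(-c3cccs3)c2)c1`, gives 9280 nM. Both compounds carry a phenol, a chlorophenyl group and a thiophene on the same core, and their two values sit close to each other. For compound 3, `Oc1cccc(-c2cc(-c3cccnc3)nc(-c3ccccc3Cl)c2)c1`, the result reported in this assay is "not determined" (no result reported), so it stands without a value of its own.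

Compound 4, `Oc1cccc(-c2cc(-c3cccs3)nc(-c3ccccc3Cl)c2)c1`, is the next member. It arises from compound 3 by the change (thiophen-2-yl in place of pyridin-3-yl on an aromatic carbon). Among the compounds with values here, because compound 3 has no value, no step can be measured from it, and the expectation for compound 4 must rest on compound 1 and compound 2, which hold the same thiophen-2-yl and 2-chlorophenyl pattern as compound 4 or differ from it only in where the hydroxyl group sits. On that basis compound 4 is expected to give a value in this assay close to those of its two measured neighbours, with no shift beyond the usual scatter in either direction. The estimate for compound 4 is 6500 nM, expected to lie between 2500 nM and 16000 nM.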

Compound 4, half-maximal inhibitory concentration: 2790 nM
Estimate against measurement, compound 4: 2.3-fold (0.37 log units) above; low and high end bracket the measured number.
By their numbers in this assay, from the lowest: compounds 4, 1 and 2 (each within the scatter of the next, the first and the last beyond it).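

In this assay, within the data shown here, 2-chlorophenyl in place of 4-chlorophenyl gives a 3.3-fold lower number from compound 2 to compound 4 (0.52 log units; beyond the scatter), the only step in this small set that lies beyond the scatter, so the place of the chlorine on this aryl group registers in the read-out, though modestly. By contrast, 3-hydroxyphenyl in place of 4-hydroxyphenyl gives a 1.9-fold lower number from compound 1 to compound 4 (0.29 log units; within the scatter), which lies within the scatter, so with the thiophen-2-yl and 2-chlorophenyl groups held constant, the place of the hydroxyl does not separate these two compounds. Nothing available here accounts for either result.

On these data alone, the exchange of pyridin-3-yl for thiophen-2-yl cannot be read, as compound 3 has no value, and the effect of this ring exchange on the read-out therefore remains unknown. The compounds shown also leave open how a methoxy group or an amine in place of the hydroxyl, or a fluorine or a methyl group in place of the chlorine, would read in this assay.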